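The compounds below may be only part of what the source reports. "The series", "measured", "known", "first", "only" and "open" are said of these compounds alone.

Measured so far in an ADME assay on microsomes from liver (Mus musculus) for metabolic stability (on this read-out higher numbers stand for a longer-lived compound and lower numbers for a shorter-lived compound), are three compounds:
- compound 1 `CCC(CC)(c1nnc[nH]1)c1ccc(-c2ccc3cc(F)cc(F)c3c2)[nH]c1=O` gives 1.09 h
- compound 2 `CC(C)C(Cc1ncc[nH]1)c1ccc(-c2ccc3cccc(F)c3c2)[nH]c1=O` gives < 0.0667 h which is a limit of the assay and not a number
- compound 3 `Cc1nc(C(c2ccc(-c3ccc4cccc(F)c4c3)[nH]c2=O)C(C)C)[nH]c1C` gives 0.0817 h

Compound 3 holds the lower of the two actual numbers, and compound 1 stands above it by more than the usual scatter. Compound 4 `CC(C)C(c1noc(=O)[nH]1)c1ccc(-c2ccc3cccc(F)c3c2)[nH]c1=O` differs from compound 3 in one place (a group of 6 heavy atoms (2 carbon, 2 nitrogen, 2 oxygen; one five-membered aromatic ring with 3 hetero atoms) in place of a group of 7 heavy atoms (5 carbon, 2 nitrogen; one five-membered aromatic ring with 2 hetero atoms), on a saturated chain carbon bound to an aromatic carbon and a saturated chain carbon), on a saturated chain carbon bound to an aromatic carbon and a saturated chain carbon.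

Among the measured compounds shown here, only one measured step touches this place: an at least 1.2-fold higher number from compound 2 to compound 3 (0.08 log units; that floor lies within the scatter) and it also exchanges one group for another. That step starts from a limit and stays within the scatter, so it offers little guidance on size or direction. Compound 1 (1.09 h) shows that a much longer half-life is possible with a different five-membered aromatic ring, but compound 1 differs from compound 3 elsewhere as well, so it supports only a cautious upward expectation. The expected step is a 3.1-fold higher number from compound 3 to compound 4 (0.49 log units; beyond the scatter) and it carries wide uncertainty. For compound 4 the estimate is 0.25 h with an expected range from 0.07 h to 0.9 h on this read-out.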

Compound 4, half-life: > 3 h
Compound 4: a limit, no number; the forecaster's own chance of this, stated with the estimate: 15%; at least 12-fold (1.07 log units) between middle value and limit.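

In this assay, putting the five-membered aromatic ring with 3 hetero atoms in place of 4,5-dimethyl-1H-imidazol-2-yl on the saturated chain carbon gives an at least 36-fold higher number from compound 3 to compound 4 (1.56 log units; beyond the scatter), so this place can have a large effect on half-life, which the earlier step, starting from a limit and staying within the scatter, could not show. The same ring in place of (1H-imidazol-2-yl)methyl points the same way, with an at least 44-fold higher number from compound 2 to compound 4 (1.65 log units; beyond the scatter). Compound 4 holds a limit of the assay and not a number, so both steps give only a floor for the change and its full size stays unknown: the limit of > 3 h in this assay, at which 1 of the 4 values shown sits.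

The compounds shown do not tell which feature of the new ring goes with the longer half-life, whether its ring atoms, its double bond outside the aromatic ring or its count of hydrogen-bond acceptors, and they give no measured property that would explain the change. Going by these compounds, it also remains open whether a ring is needed at this place at all, which a carboxylic acid or a primary amide on the same saturated chain carbon could test.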